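Chloro in place of hydrogen on the core of compound 3

The source may report more compounds than this note shows. Statements on the series, on what has been measured and on what is new or still open speak of the compounds shown alone.

Compound 1 `ClCc1ccc(Cn2cnc3c(Cl)ncnc32)cc1` gives 1380 nM in a functional assay on OVCAR-3 cells (Homo sapiens) for cytotoxicity, read by sulforhodamine B assay, with a stated time of 48 h; on this read-out higher numbers stand for weaker inhibition of growth and lower numbers for stronger inhibition of growth. Compound 2 `Nc1nc(Cl)c2ncn(Cc3ccc(CCl)cc3)c2n1` gives 2140 nM in this assay, and the step of a 1.6-fold higher number from compound 1 to compound 2 (0.19 log units; within the scatter) is within the scatter. Compound 3 `ClCc1cccc(Cn2cnc3c(Cl)ncnc32)c1` gives 1620 nM in this assay, the second highest of the three numbers, within the scatter of compound 1 and of compound 2. Compound 4 `ClCc1cccc(Cn2cnc3c(Cl)nc(Cl)nc32)c1` differs from compound 3 by chloro in place of hydrogen on an aromatic carbon. Within the data shown here, the only measured step, a 1.6-fold higher number from compound 1 to compound 2 (0.19 log units; within the scatter), also puts a group on that aromatic carbon of the core and stayed within the scatter; no chloro-for-hydrogen step has been measured. An estimated step of a 1.0-fold lower number from compound 3 to compound 4 (0.01 log units; within the scatter) in this assay is therefore expected, not beyond the scatter. Compound 4 is estimated at 1600 nM in this assay, with a range from 700 nM to 3600 nM.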

Compound 4, concentration for 50% growth inhibition: 1580 nM
Beside the measured number, compound 4's estimate is 1.0-fold (0.01 log units) above it; the measured number falls inside the stated range.
By their numbers in this assay, from the lowest: compounds 1, 4, 3 and 2 (each within the scatter of the next).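

In this assay, chloro in place of hydrogen on the aromatic carbon between two ring nitrogen atoms gives a 1.0-fold lower number from compound 3 to compound 4 (0.01 log units; within the scatter), the first chloro-for-hydrogen step read at this position. Together with amino in place of hydrogen, a 1.6-fold higher number from compound 1 to compound 2 (0.19 log units; within the scatter), read on a different parent, two different groups have now been placed on this carbon, and neither step leaves the scatter. No evidence at hand gives a reason for this result. Open, on these data alone, is whether a methoxy group, a carboxylic acid or a longer chain on this carbon would also stay within the scatter.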